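Benzophenone ether series: acid replaces methyl ester

The compounds below may be only part of what the source reports. "The series", "measured", "known", "first", "only" and "open" are said of these compounds alone.

Measured compounds:
- compound 1, `COC(=O)c1ccc(OCCCCOc2ccc(C(=O)CC3CCCC3)c(O)c2C)cc1`: an assay on HEK293 cells for positive allosteric modulation of metabotropic glutamate receptor 2 (Rattus norvegicus), read by thallium flux, with a stated time of 2.5 min (on this read-out lower numbers stand for an effect already at smaller amounts and higher numbers for an effect only at larger amounts of compound), gives "not determined" (no result reported)
- compound 2, `COc1ccc(C(=O)O)cc1OCCCCOc1ccc(C(=O)C(C)C)c(O)c1C`: this assay gives 116 nM
- compound 3, `COC(=O)c1ccc(OCCCCOc2ccc(C(=O)CC(C)C)c(O)c2C)cc1`: this assay gives "not determined" (no result reported)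

Among the measured compounds shown here, compound 3 carries no single number; the same holds for compound 1, so the only number on hand is that of compound 2, which is a carboxylic acid on the aryl ether end rather than a methyl ester. Compound 4, `Cc1c(OCCCCOc2ccc(F)c(C(=O)O)c2)ccc(C(=O)CC(C)C)c1O`, is built from compound 3 by the change (3-carboxy-4-fluorophenyl in place of 4-(methoxycarbonyl)phenyl on an oxygen on a saturated carbon). For the measured compounds named here, no step between measured compounds is on hand, so the size of this step cannot be read from the data. Given that compound 2 gives 116 nM, a carboxylic-acid analogue in the same series already has a measured value, and compound 4 is expected to land in a similar region; a step beyond the scatter relative to compound 3 cannot be judged without a number for compound 3. Compound 4 is therefore estimated at 160 nM, with a range of 50 nM to 500 nM.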

Compound 4, half-maximal effective concentration: 153 nM
For compound 4 the middle estimate is 1.0-fold (0.02 log units) above the measured one; low and high end bracket the measured number.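

Among the compounds shown here, compound 3 carries no single number, so no step to compound 4 can be read. Nothing on hand bears on the cause of the result. The compounds shown leave open whether 3-carboxy-4-fluorophenyl in place of 4-(methoxycarbonyl)phenyl shifts the read-out at all, and by how much.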